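Benzyl for Dimethylphenyl: Expected Permeability of Compound 4

A few compounds are considered here, and "the series" means these few. Any claim that something is new, unique, unknown or untested is made for them only; others in the source may bear on it.

Measured compounds:
Compound 1, `COc1ccc(F)cc1CNCCCNc1ccnc2cc(Cc3cc(C)cc(C)c3)ccc12`: 23 10^-6 cm/s
Compound 2, `CC(C)CCc1ccc2c(NCCCNCc3ccco3)ccnc2c1`: 23 10^-6 cm/s
Compound 3, `Fc1ccc(Cc2ccc3c(NCCCNCc4ccco4)ccnc3c2)c(Cl)c1`: 23 10^-6 cm/s

Of the compounds shown here, three sharing one core have been measured in an ADME assay for permeability, using PAMPA, with a stated time of 30 min, at pH 7.4; on this read-out lower numbers stand for lower permeability and higher numbers for higher permeability. Compound 1 stands level with the other two: in this assay compound 1 gives 23 10^-6 cm/s, and the values of compound 2 and compound 3 sit at the same digits, so no order can be read among them.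

Compound 4, `COc1ccc(F)cc1CNCCCNc1ccnc2cc(CCc3ccccc3)ccc12`, has not yet been measured. It differs from compound 1 in one place: benzyl in place of 3,5-dimethylphenyl on a saturated chain carbon bound to an aromatic carbon.

Among the compounds with values here, only one measured step sits at the same place on the core, the saturated chain carbon bound to an aromatic carbon. There, no change at the digits printed from compound 2 to compound 3 (within the scatter), even though the group on that carbon went from isobutyl to 2-chloro-4-fluorophenyl. The change from compound 1 to compound 4 is smaller in kind, one six-membered aromatic ring of carbon only being replaced by another. On that evidence, no step beyond the scatter is expected in this assay, in either direction, and no change at the digits printed from compound 1 to compound 4 (within the scatter) is the expected outcome. Compound 4 is therefore estimated at 23 10^-6 cm/s, with a range from 12 10^-6 cm/s to 42 10^-6 cm/s.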

Compound 4, apparent permeability: 23 10^-6 cm/s
For compound 4 middle estimate and measured number coincide at the digits printed, within the range that was stated.
By their numbers in this assay, from the lowest: compounds 1, 2, 3 and 4 (each within the scatter of the next).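

In this assay, within the data shown here, the exchange of 3,5-dimethylphenyl for benzyl on a saturated chain carbon bound to an aromatic carbon gives no change at the digits printed from compound 1 to compound 4 (within the scatter), and this is the first step at this place on the core of compound 1. Before it, the only step at this place was no change at the digits printed from compound 2 to compound 3 (within the scatter), so the new pair adds a second case in which the read-out holds when the group on that carbon is exchanged, here for one that also carries a single six-membered aromatic ring of carbon only. No measurement shown here explains why the read-out holds in either pair.

The compounds shown leave open whether a carboxylic acid, an amine or a longer chain such as phenylpropyl at this place would keep the value in this assay where it stands. Since all four compounds print the same digits, they also leave open which exchange at this place, if any, would give a step beyond the scatter.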